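The source may report more compounds than this note shows. Statements on the series, on what has been measured and on what is new or still open speak of the compounds shown alone.

Working notes on the pyrrolidine amide series.

Of the compounds shown here, three have been measured so far in an assay on HEK293 cells for inhibition of N-acylethanolamine-hydrolyzing acid amidase (Rattus norvegicus), read by LC-MS, with a stated time of 30 min; on this read-out higher numbers stand for weaker inhibition and lower numbers for stronger inhibition. Compound 1 `Cc1cccc(CCCCCCC(=O)N2CCCC2)c1` gives 8300 nM. Compound 2 `O=C(CCc1ccc(-c2ccc(F)cc2)cc1)N1CCCC1` gives 3400 nM. Compound 3 `O=C(CCCCCCc1cccs1)N1CCCC1` gives 14100 nM. On these numbers compound 2 stands lowest: its gap to compound 1, the nearest of the other two, lies beyond the usual scatter, and its gap to compound 3, the furthest, is wider still. Compound 2 is therefore the strongest inhibitor of the three measured. Within the data shown here, no pair among the measured compounds differs in a single place, so no step between them can be read directly.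

The next compound to go into this assay is compound 4 `O=C(CCc1ccc(OC2CCCCC2)cc1)N1CCCC1`. It differs from compound 2 in one place (cyclohexyloxy in place of 4-fluorophenyl on an aromatic carbon). Nothing in the measured set tracks this kind of exchange, so the expectation rests on compound 2 alone. Given that compound 2 gives 3400 nM, compound 4 is expected to land near that figure, with a step of a 1.3-fold higher number from compound 2 to compound 4 (0.12 log units; within the scatter) that is expected to stay within the scatter or drift slightly weaker. For compound 4 the estimated value is 4500 nM, with a range from 1500 nM to 14000 nM.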

Compound 4, half-maximal inhibitory concentration: 700 nM
Beside the measured number, compound 4's estimate is 6.4-fold (0.81 log units) above it; the measured number lies below the stated range.
By their numbers in this assay, from the lowest: compound 4; then compound 2; then compounds 1 and 3 (each within the scatter of the next).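

In this assay, among these compounds, cyclohexyloxy in place of 4-fluorophenyl, on the aromatic carbon para to a group of 9 heavy atoms, brings a 4.9-fold lower number from compound 2 to compound 4 (0.69 log units; beyond the scatter), the first single-place step, and it shows that this position responds to the group it carries. Both groups have 7 heavy atoms and one six-membered ring, yet the entering group has a non-aromatic ring and 1 hydrogen-bond acceptor, so in this pair an aromatic ring on this carbon is not needed for the stronger inhibition. No measurement here bears on the reason for this step.

The step changes the ring and the oxygen together, so the compounds shown do not separate the two: phenoxy would keep the oxygen with an aromatic ring, while cyclohexyl would keep the non-aromatic ring without the oxygen. From the compounds shown here alone, it also remains open whether a smaller ring such as cyclopentyloxy or an open chain such as hexyloxy would hold the gain, and whether the same exchange would act alike on a longer chain between the aromatic ring and the amide carbonyl.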